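Removing a methoxy from the fused ring of compound 2

A few compounds are considered here, and "the series" means these few. Any claim that something is new, unique, unknown or untested is made for them only; others in the source may bear on it.

Measured compounds:
compound 1, `N#C/C(=C\c1c(-c2ccccc2)[nH]c2ccccc12)C(=O)c1ccccc1`: "not determined" (no result reported) in a functional assay on MOLT-4 cells (Homo sapiens) for inhibition, read by sulforhodamine B assay, with a stated time of 48 h; on this read-out higher numbers stand for weaker inhibition of growth and lower numbers for stronger inhibition of growth
compound 2, `COc1ccc(-c2[nH]c3ccc(OC)cc3c2/C=C(\C#N)S(=O)(=O)c2ccccc2)cc1`: 765 nM

Within the data shown here, compound 2 is the only compound with a number on this read-out, so it has no partner to be compared against; for compound 1 the growth-inhibition assay gave no result at all. Compound 3, `COc1ccc(-c2[nH]c3ccccc3c2/C=C(\C#N)S(=O)(=O)c2ccccc2)cc1`, is the untested compound. It differs from compound 2 in one place: hydrogen in place of methoxy on an aromatic carbon. Both compounds keep the same shared core and the same methoxy on the pendant phenyl ring; only the methoxy on the fused ring is gone.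

Among the measured compounds shown here, with no measured pair that shows the effect of such a removal, there is no basis for expecting a large shift in this assay. The step from compound 2 to compound 3 is expected to stay within the usual scatter, a 1.2-fold higher number from compound 2 to compound 3 (0.07 log units; within the scatter). Compound 3 is therefore estimated at 900 nM, within a range from 300 nM to 2700 nM.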

Compound 3, concentration for 50% growth inhibition: 871 nM
Estimate against measurement, compound 3: 1.0-fold (0.01 log units) above, within the range that was stated.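

In this assay, replacing the methoxy on the fused ring with hydrogen gives a 1.1-fold higher number from compound 2 to compound 3 (0.06 log units; within the scatter), so the two compounds cannot be told apart on this read-out. Among these compounds, this is the first measured pair, and it shows that compound 3 keeps growth inhibition in the same range as compound 2 without this methoxy, so the group is not needed at this carbon. No separate measurement bears on why the swap leaves the number so close.

As far as these compounds go, this single pair covers only hydrogen and methoxy at this carbon, so it remains open whether an amine, a carboxylic acid or a longer chain there would also leave the read-out in place. The methoxy on the pendant phenyl ring also remains untested by any pair shown, and compound 1, with no result, adds no comparison.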